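This account rests on a few compounds, and the source may have more. Where it says the series, first, only, none or still open, it means among the compounds named here.

In a functional assay on MDA-MB-231 cells (Homo sapiens) for cytotoxicity, read by MTT assay, with a stated time of 48 h (on this read-out higher numbers stand for weaker inhibition and lower numbers for stronger inhibition), compound 1 `O=C(NCCCCC(c1ccc(F)cc1)c1ccc(F)cc1)Nc1ccc(Cl)cc1` gives 7680 nM. Compound 2 `Cc1ccc(NC(=O)NCCCCC(c2ccc(F)cc2)c2ccc(F)cc2)cc1` reads > 20000 nM, which is a limit and not a number. Compound 3 `Cc1ccc(NC(=O)NCCCCC(c2ccc(F)cc2)c2ccc(F)cc2)cc1C` reads > 20000 nM, which is also only a limit. This is the limit of > 20000 nM in this assay, at which 2 of the 3 values shown sit, so the two limits leave the comparison unresolved: a step that the two limits leave unreadable from compound 2 to compound 3.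

Compound 4 `O=C(NCCCCC(c1ccc(F)cc1)c1ccc(F)cc1)Nc1ccc(Br)cc1I` departs from compound 3 in one place: 4-bromo-2-iodophenyl in place of 3,4-dimethylphenyl on an amide-type nitrogen. Thus 4-bromo-2-iodophenyl stands in place of 3,4-dimethylphenyl on an amide-type nitrogen.

Among the measured compounds shown here, two measured steps bear on this change, both beyond the scatter and both known only as lower bounds: an at least 2.6-fold higher number from compound 1 to compound 2 (0.41 log units; beyond the scatter), and an at least 2.6-fold higher number from compound 1 to compound 3 (0.41 log units; beyond the scatter). Each leaves the 4-chlorophenyl of compound 1 for a methylated ring and moves the reading to the limit. For the measured compounds named here, the change to compound 4 runs the opposite way, from a methylated ring to a halogenated one, although no bromo or iodo compound has yet been measured. A drop to a lower number is therefore expected, of a size comparable to those steps, with a real chance that the reading stays at the limit.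

The expected change is an at least 2.5-fold lower number from compound 3 to compound 4 (0.39 log units; beyond the scatter).

Compound 4 is estimated at 8000 nM, with an expected range from 3000 nM to 20000 nM.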

Compound 4, half-maximal inhibitory concentration: > 20000 nM
Compound 4 was reported as a limit; the forecaster's own chance of this, stated with the estimate: 25%; middle value at least 2.5-fold (0.39 log units) away from the limit.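

Replacing the 4-chlorophenyl with 4-bromo-2-iodophenyl on the amide-type nitrogen gives an at least 2.6-fold higher number from compound 1 to compound 4 (0.41 log units; beyond the scatter), so a halogenated ring in this place does not by itself preserve the measurable reading of compound 1. In this assay, compound 4 gives > 20000 nM, which is a limit and not a number. The steps among compound 2, compound 3 and compound 4 cannot be read, and compound 1 remains the only one of the four with a number: the limit of > 20000 nM in this assay, at which 3 of the 4 values shown sit.

The compounds shown do not tell whether the bromo group, the iodo group or the two together separate compound 4 from compound 1, a question that a 4-bromophenyl or a 2-iodophenyl group on the same nitrogen would address. They also leave open how far the readings of compound 2, compound 3 and compound 4 lie beyond the limit, and whether a 4-methoxyphenyl group or a ring carrying a carboxylic acid would give a number here.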